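A few compounds are considered here, and "the series" means these few. Any claim that something is new, unique, unknown or untested is made for them only; others in the source may bear on it.

Of the compounds shown here, two have been measured in a functional assay for inhibition of sodium/hydrogen exchanger (Oryctolagus cuniculus); a higher number here means a weaker inhibitor, a lower number a stronger inhibitor. Compound 1 `Cc1cc(C)c(S(C)(=O)=O)cc1C(=O)N=C(N)N` gives 11 nM. Compound 2 `Cc1cc(N2CCCC2)c(S(C)(=O)=O)cc1C(=O)N=C(N)N`, which carries a pyrrolidin-1-yl in place of the methyl on an aromatic carbon, gives 11 nM; the step of no change at the digits printed from compound 1 to compound 2 (within the scatter) shows that swapping these two groups at this position made no difference that rises above the scatter. For the measured compounds named here, compound 2 therefore stands level with compound 1 on the numbers so far.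

Compound 3 `Cc1ccc(S(C)(=O)=O)cc1C(=O)N=C(N)N` is the next compound. Its difference from compound 2 is hydrogen in place of pyrrolidin-1-yl on an aromatic carbon. Going by the values given here, the only measured step that bears on this position is the one from compound 1 to compound 2, and it was flat, which suggests that the position tolerates both a small and a larger group without a shift in potency. Removing the group altogether is not the same change, so some uncertainty remains, but no direction is indicated.

Compound 3 is expected to give 12 nM, within 5 nM to 35 nM, in this assay. The expected step of a 1.1-fold higher number from compound 2 to compound 3 (0.04 log units; within the scatter) is estimated to lie within the scatter.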

Compound 3, half-maximal inhibitory concentration: 150 nM
The estimate for compound 3 lay 13-fold (1.10 log units) below the measured number; measured number outside the range, above it.
By their numbers in this assay, from the lowest: compounds 1 and 2 (each within the scatter of the next); then compound 3.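

In this assay, exchanging one group for another at this position changed nothing, but removing the group altogether matters a great deal: hydrogen in place of pyrrolidin-1-yl gives a 14-fold higher number from compound 2 to compound 3 (1.13 log units; beyond the scatter), and hydrogen in place of methyl gives a 14-fold higher number from compound 1 to compound 3 (1.13 log units; beyond the scatter). The flat step between compound 1 and compound 2 therefore did not mean that the position is indifferent; it meant only that these two quite different groups sit level with each other, while the bare aromatic carbon of compound 3 falls well behind both. Nothing measured here accounts for this gap between hydrogen and the two groups.

As far as these compounds go, it remains open whether almost any substituent on this carbon would keep the number level with compound 1 and compound 2, or whether that holds only for some, such as a chlorine atom, a methoxy group, a primary amine or a carboxylic acid. From the compounds shown here alone, it is also open how far the size of the group can grow, for instance to a piperidine ring, a phenyl ring or a longer alkyl chain, before the number moves.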